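Adding a methoxy: expected step within scatter

The source may hold more compounds than are shown below. What is called first, only, known or untested is meant among the compounds shown, and "the series" means these compounds.

In a functional assay on Hs 683 cells (Homo sapiens) for inhibition, read by colorimetric assay and MTT assay, with a stated time of 72 h (a higher number here means a weaker inhibitor, a lower number a stronger inhibitor), compound 2 `COc1ccc(C(=O)NNC(=S)Nc2csc(-c3ccccc3)c2)cc1` gives 35000 nM; compound 1 `COc1cc(C(=O)NNC(=S)Nc2csc(-c3ccccc3)c2)cc(OC)c1OC` gives 42000 nM in this assay, a gap within the scatter, so the two read alike and neither stands apart. Compound 3 `COc1ccc(C(=O)NNC(=S)Nc2csc(-c3ccccc3)c2)cc1OC` differs from compound 2 by methoxy in place of hydrogen on an aromatic carbon. Among the compounds with values here, no step between measured compounds is available for this change; since compound 1 and compound 2 show no difference beyond the scatter, the expected step of a 1.1-fold higher number from compound 2 to compound 3 (0.04 log units; within the scatter) is none beyond the scatter. Compound 3 is expected to give about 38000 nM in this assay, estimated to lie between 18000 nM and 80000 nM.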

Compound 3, half-maximal inhibitory concentration: 22000 nM
The estimate for compound 3 lay 1.7-fold (0.24 log units) above the measured number; the range from low to high includes it.
By their numbers in this assay, from the lowest: compounds 3, 2 and 1 (each within the scatter of the next).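

Methoxy in place of hydrogen, at the aromatic carbon ortho to a methoxy group and meta to a large group, gives a small step in this assay (a 1.6-fold lower number from compound 2 to compound 3 (0.20 log units; within the scatter)), and hydrogen in place of methoxy gives another (a 1.9-fold lower number from compound 1 to compound 3 (0.28 log units; within the scatter)). Both steps lie within the scatter, so this position shows no readable preference between hydrogen and methoxy in this assay. No supporting data bear on these numbers. From the compounds shown here alone, whether an amine, a carboxylic acid or a longer chain such as ethoxy at this position would move the number beyond the scatter remains open.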